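Furan for Oxazole: Expected Cytotoxicity of Compound 4

The compounds below may be only part of what the source reports. "The series", "measured", "known", "first", "only" and "open" are said of these compounds alone.

Compound 3 `O=C(Nc1ccc(Cl)cc1)C1CCCN(C(=O)c2cccc(-c3cnco3)c2)C1` belongs to a set of three compounds with a shared core that were tested in an ADME assay on PC-3 cells (Homo sapiens) for cytotoxicity, read by WST assay, tested at 100 uM; a lower number here means less inhibition, a higher number more inhibition at the concentration tested (going by the name of the read-out). In this assay compound 3 gives 0%. Compound 1 `CSc1cccc(C(=O)N2CCCC(C(=O)Nc3ccc(Cl)cc3)C2)c1` gives 0% in this assay, and compound 2 `N#Cc1cccc(C(=O)N2CCCC(C(=O)Nc3ccc(Cl)cc3)C2)c1` gives 0% in this assay. The three stand level with one another: no change at the digits printed from compound 1 to compound 2 (within the scatter), no change at the digits printed from compound 1 to compound 3 (within the scatter), and no change at the digits printed from compound 2 to compound 3 (within the scatter). Compound 4 `O=C(Nc1ccc(Cl)cc1)C1CCCN(C(=O)c2cccc(-c3ccco3)c2)C1` has not yet been measured. It differs from compound 3 in one place: furan-2-yl in place of 1,3-oxazol-5-yl on an aromatic carbon. The measured steps bear on this change in that each of them exchanges a group on an aromatic carbon of the shared core, namely methylsulfanyl, cyano and 1,3-oxazol-5-yl, and none of them moves the read-out in this assay beyond the scatter. For the measured compounds named here, no measured step exchanges one five-membered aromatic ring for another, so the furan-2-yl case is not covered directly. On these grounds the expected step in this assay is no change at the digits printed from compound 3 to compound 4 (within the scatter), which is no change beyond the scatter. Compound 4 is therefore estimated at 0% in this assay, with a range from -10% to 12%.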

Compound 4, a percentage reported as inhibition, at one concentration (the size of the read-out at that concentration, not a potency): 0%
The estimate for compound 4 equals the measured number at the digits printed, and the stated range covers the measured number.
By their numbers in this assay, from the lowest: compounds 1, 2, 3 and 4 (each within the scatter of the next).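

At this position, on an aromatic carbon of a six-membered aromatic ring of carbon only and meta to a large group, the exchange of one five-membered aromatic ring for another now has a reading in this assay and it is no change at the digits printed from compound 3 to compound 4 (within the scatter) for furan-2-yl in place of 1,3-oxazol-5-yl. Furan-2-yl also stands level with the two groups that carry no ring, with no change at the digits printed from compound 2 to compound 4 (within the scatter) for the exchange with cyano and no change at the digits printed from compound 1 to compound 4 (within the scatter) for the exchange with methylsulfanyl. Nothing in the data accounts for this flat reading across all four groups.

From the compounds shown here alone, whether an amine or a carboxylic acid at this position would lift the reading in this assay away from that of compound 3 at 0% remains open. Also open, going by these compounds, is whether a change elsewhere on the shared core would move the reading, since all four compounds differ only in this one group.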